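Thienyl series: replacing methylamino with methyl

The source may hold more compounds than are shown below. What is called first, only, known or untested is meant among the compounds shown, and "the series" means these compounds.

Values in a functional assay on HCT-116 cells (Homo sapiens), read by MTT assay, with a stated time of 72 h; a lower number here means a stronger inhibitor, a higher number a weaker inhibitor:
- compound 1 `CNc1ncnc2c1c(-c1cccs1)cn2[C@@H]1O[C@H](CO)[C@@H](O)[C@H]1O`: > 20000 nM
- compound 2 `CNc1ncnc2c1c(-c1ccccc1)cn2[C@@H]1O[C@H](CO)[C@@H](O)[C@H]1O`: > 100000 nM

Compound 1 stands only at a limit, > 20000 nM. Compound 2 likewise gives only a limit, > 100000 nM. Among the compounds with values here, the one measured step is a step that the two limits leave unreadable from compound 1 to compound 2. It concerns a different change and gives no size to carry over.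

Compound 3 `Cc1ncnc2c1c(-c1cccs1)cn2[C@@H]1O[C@H](CO)[C@@H](O)[C@H]1O` differs from compound 1 as follows: methyl in place of methylamino on an aromatic carbon. Within the data shown here, no measured step covers this change, so its size is poorly constrained. A move toward stronger inhibition in this assay is expected, since a measurable value for compound 3 could lie only on that side of the limit of compound 1. The estimated step is an at least 10-fold lower number from compound 1 to compound 3 (1.00 log units; beyond the scatter). Compound 3 is estimated at 2000 nM, with an expected range from 150 nM to 20000 nM.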

Compound 3, half-maximal inhibitory concentration: > 20000 nM
Compound 3: no number, only a limit (the forecaster's own chance of this, stated with the estimate: 20%); middle value at least 10-fold (1.00 log units) away from the limit.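

In this assay compound 3 gives only a limit, > 20000 nM. Within the data shown here, compound 1 also stands only at a limit, and no step between compound 1 and compound 3 can be read. Whether methyl in place of methylamino changes inhibition at all remains open, as none of the compounds shown gives an exact value.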